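This account rests on a few compounds, and the source may have more. Where it says the series, first, only, none or still open, it means among the compounds named here.

Of the compounds shown here, three of a shared core have been measured in a functional assay on PC-3 cells (Homo sapiens) for antiproliferative activity, read by MTT assay, with a stated time of 48 h; on this read-out higher numbers stand for weaker inhibition and lower numbers for stronger inhibition. Compound 1 `C#CCOc1ccc(/C=C/C(C)=O)cc1OC` gives 40200 nM and compound 2 `COc1cc(/C=C/C(C)=O)ccc1OCc1cn(-c2ccc(/N=N/c3ccccc3)cc2)nn1` gives 42100 nM. Compound 3 `COc1ccc(-n2cc(COc3ccc(/C=C/C(C)=O)cc3OC)nn2)cc1` gives 2010 nM, the lowest of the three numbers, and both of the other two stand beyond the scatter above it. Among the compounds with values here, the one step that can be compared within a single change is a 21-fold lower number from compound 2 to compound 3 (1.32 log units; beyond the scatter), in which a small group replaced a much larger one on the aromatic ring attached to the triazole. Compound 4 `COc1cc(/C=C/C(C)=O)ccc1OCc1cn(-c2ccccc2OC)nn1` keeps every atom of compound 3 but rearranges one group: 2-methoxyphenyl in place of 4-methoxyphenyl on an aromatic nitrogen. Within the data shown here, no measured step here moves a group around a ring in this way, so the expectation rests on the absence of any comparable step rather than on a direct precedent. Only a modest shift is therefore expected, a 1.7-fold higher number from compound 3 to compound 4 (0.24 log units; within the scatter), with the number for compound 4 estimated at 3500 nM and a plausible range from 1000 nM to 12000 nM.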

Compound 4, half-maximal inhibitory concentration: 2050 nM
Compound 4: the middle estimate sits 1.7-fold (0.23 log units) above what was measured; the measured number falls inside the stated range.
By their numbers in this assay, from the lowest: compounds 3 and 4 (each within the scatter of the next); then compounds 1 and 2 (each within the scatter of the next).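

In this assay, 2-methoxyphenyl in place of 4-methoxyphenyl on the aromatic nitrogen gives a 1.0-fold higher number from compound 3 to compound 4 (0.01 log units; within the scatter), so moving the methoxy group around this phenyl ring does not separate the two compounds. The earlier step, a 21-fold lower number from compound 2 to compound 3 (1.32 log units; beyond the scatter), showed that changing the group this ring carries can matter greatly, whereas this pair shows that, for methoxy, these two places on the ring give numbers within the scatter of each other. Nothing available here explains why the two numbers match.

From the compounds shown here alone, it remains open how 3-methoxyphenyl would compare on the same nitrogen. Going by these compounds, it is also open whether a different group on this ring, such as an amine or a carboxylic acid, would tolerate the same move.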